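The compounds below may be only part of what the source reports. "The series", "measured", "known", "first", "only" and "open" are said of these compounds alone.

The study follows cytotoxicity in a functional assay on HeLa cells (Homo sapiens) for cytotoxicity, read by cell counting, with a stated time of 4 days; a higher number here means a weaker inhibitor, a lower number a stronger inhibitor. Compound 1 `C=C(Br)C(=O)Nc1ccc(/C=C2\SC(=O)N(Cc3ccccc3)C2=O)cc1` gives 1000 nM in this assay. Compound 3 `Nc1ccc(/C=C2\SC(=O)N(Cc3cccc(F)c3)C2=O)cc1` gives 250000 nM in this assay. For compound 2 `Nc1cccc(/C=C2\SC(=O)N(Cc3ccccc3)C2=O)c1` this assay reports only a limit, > 250000 nM. Of the two values that are actual numbers, compound 3 stands at the higher one, and compound 1 sits far lower, a gap that lies well beyond the scatter. One of the three values rests at a limit, namely (the limit of > 250000 nM in this assay, at which 1 of the 3 values shown sits).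

Compound 4 `Nc1ccc(/C=C2\SC(=O)N(Cc3ccccc3)C2=O)cc1` has not yet been measured in this assay. It differs from compound 3 in one place: hydrogen in place of fluoro on an aromatic carbon. Among the measured compounds shown here, no measured pair shows this change, so its effect is unknown. The two measured amines, compound 2 and compound 3, both show very weak inhibition in this assay, and compound 4 is expected to behave alike. The step of no change at the digits printed from compound 3 to compound 4 (within the scatter) is expected to be small, within the scatter, in either direction. Compound 4 is thus expected to give about 250000 nM in this assay, within 100000 nM to 400000 nM, with a fair chance that only a limit is reported.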

Compound 4, half-maximal inhibitory concentration: 46000 nM
Beside the measured number, compound 4's estimate is 5.4-fold (0.74 log units) above it, outside the stated range (below it).
By their numbers in this assay, from the lowest: compound 1; then compound 4; then compound 3.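

In this assay, among the compounds shown here, hydrogen in place of fluoro on an aromatic carbon gives a 5.4-fold lower number from compound 3 to compound 4 (0.74 log units; beyond the scatter), so this place on the 3-fluorophenyl group changes the number, which no earlier pair could show. 4-Aminophenyl in place of 3-aminophenyl gives an at least 5.4-fold lower number from compound 2 to compound 4 (0.73 log units; beyond the scatter), a step that starts from a limit of the assay: the limit of > 250000 nM in this assay, at which 1 of the 4 values shown sits. Hydrogen in place of (1-bromoethenyl)carbonyl on the nitrogen gives a 46-fold higher number from compound 1 to compound 4 (1.66 log units; beyond the scatter), a large step that ties the low number of the series to that group on the nitrogen.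

The compounds shown leave open whether this step needs the bromine, which an acetyl or acryloyl group on the same nitrogen would test. They also leave open how a chloro or methyl group in place of fluoro on the aromatic carbon would compare.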